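This account rests on a few compounds, and the source may have more. Where it says the series, first, only, none or still open, it means among the compounds named here.

Measured so far in a functional assay on A549 cells (Homo sapiens) for antiproliferative activity, read by MTT assay; a higher number here means a weaker inhibitor, a lower number a stronger inhibitor:
- compound 1, `Cc1ccc(NC(=O)Nc2cccc(CNc3ncnc4ccccc34)c2)cc1`: 24900 nM
- compound 2, `COc1ccc(NC(=O)Nc2cccc(CNc3ncnc4ccccc34)c2)cc1`: 29300 nM
- compound 3, `CC(C)(C)c1ccc(NC(=O)Nc2cccc(CNc3ncnc4ccccc34)c2)cc1`: 17900 nM

Compound 3 has the lowest of the three numbers in this assay, but the gaps to compound 1 and to compound 2 are both within the scatter, so no order among the three can be read from this. The measured steps all vary the group on an aromatic carbon of the aryl urea: a 1.2-fold higher number from compound 1 to compound 2 (0.07 log units; within the scatter), a 1.4-fold lower number from compound 1 to compound 3 (0.14 log units; within the scatter), and a 1.6-fold lower number from compound 2 to compound 3 (0.21 log units; within the scatter); each of them stays within the scatter.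

Compound 4, `O=C(Nc1cccc(Cl)c1)Nc1cccc(CNc2ncnc3ccccc23)c1`, is the next step: 3-chlorophenyl in place of 4-(tert-butyl)phenyl on an amide-type nitrogen. For the measured compounds named here, none of the measured steps exchanges a whole aryl group or introduces a chlorine, so they bear only loosely on this change; what they show is that changing the substituent on this phenyl ring has not moved the number in this assay beyond the scatter in three tries. By that reading no step beyond the scatter is expected here either, in either direction.

Compound 4 is therefore estimated at 22000 nM in this assay, with a range of 9000 nM to 55000 nM, which corresponds to an expected step of a 1.2-fold higher number from compound 3 to compound 4 (0.09 log units; within the scatter).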

Compound 4, half-maximal inhibitory concentration: > 50000 nM
Compound 4: only a limit was reported (the forecaster's own chance of this, stated with the estimate: 10%); at least 2.2-fold (0.35 log units) between middle value and limit.
By their numbers in this assay, from the lowest: compounds 3, 1 and 2 (each within the scatter of the next). At a limit, above all of these: compound 4.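

In this assay compound 4 gives > 50000 nM, which is a limit of the assay and not a number: the limit of > 50000 nM in this assay, at which 1 of the 4 values shown sits.

For the compounds shown here, exchanging 4-(tert-butyl)phenyl for 3-chlorophenyl on the amide-type nitrogen gives the only step that is beyond the scatter, an at least 2.7-fold higher number from compound 3 to compound 4 (0.44 log units; beyond the scatter), so the aryl group at this position can move the number, which the earlier substituent changes did not show. The comparisons with the 4-methoxyphenyl and 4-methylphenyl compounds are less firm, an at least 1.7-fold higher number from compound 2 to compound 4 (0.23 log units; that floor lies within the scatter) and an at least 2.0-fold higher number from compound 1 to compound 4 (0.30 log units; that floor lies within the scatter), with both floors within the scatter, so separation from these two is not established.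

The compounds shown cannot separate the loss of the tert-butyl group from the entry of the chlorine, and the limit leaves the actual size of all three steps unknown. Going by these compounds, how an unsubstituted phenyl, or a phenyl carrying an amine or a carboxylic acid, would read in this assay at this position also remains open.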